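A nitro group on the benzyl of compound 3

This account rests on a few compounds, and the source may have more. Where it says the series, first, only, none or still open, it means among the compounds named here.

Measured in a physicochemical assay for metabolic stability, at 50 degrees C, tested at 5 uM; a higher number here means that the compound lasts longer, a lower number that the compound disappears faster:
- compound 1 `Nc1ncnc2c1ncn2[C@@H]1O[C@@H]2CO[P@@](=O)(OCc3ccccc3)O[C@H]2[C@H]1O`: 0.5 h
- compound 2 `Nc1ncnc2c1ncn2[C@@H]1O[C@@H]2CO[P@@](=O)(OCc3ccc([N+](=O)[O-])cc3)O[C@H]2[C@H]1O`: 73 h
- compound 3 `Nc1ncnc2c1ncn2[C@@H]1O[C@@H]2CO[P@](=O)(OCc3ccccc3)O[C@H]2[C@H]1O`: 2.2 h

Compound 3 holds the middle of the three numbers, with compound 1 lower and compound 2 higher. Its gap to the lowest number is a 4.4-fold higher number from compound 1 to compound 3 (0.64 log units; beyond the scatter), and that gap can be traced only to the fact that compounds 1 and 3 differ only in the configuration as drawn.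

Compound 4 `Nc1ncnc2c1ncn2[C@@H]1O[C@@H]2CO[P@](=O)(OCc3ccccc3[N+](=O)[O-])O[C@H]2[C@H]1O` is compound 3 with a single change, (nitro in place of hydrogen on an aromatic carbon). Benzyl becomes 2-nitrobenzyl, with the nitro group on an aromatic carbon, ortho to a large group.

One measured step carries the same exchange of hydrogen for nitro, and it is large and upward: a 150-fold higher number from compound 1 to compound 2 (2.16 log units; beyond the scatter). It is an imperfect guide. It was measured on the other configuration at phosphorus, and compound 2 has its nitro group at a different place on the ring. The direction therefore carries over with more confidence than the size. The configuration step matters only as part of the starting point, which compound 3 already includes.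

Within the data shown here, a large upward step is expected, probably somewhat smaller than the one seen with compound 2. The expected change is a 45-fold higher number from compound 3 to compound 4 (1.66 log units; beyond the scatter) (an estimate). In this assay the estimated half-life for compound 4 is 100 h with an expected range of 15 h to 500 h (an estimate, not a measurement).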

Compound 4, half-life: 300 h
Compound 4: the middle estimate sits 3.0-fold (0.48 log units) below what was measured; low and high end bracket the measured number.
By their numbers in this assay, from the lowest: compound 1; then compound 3; then compound 2; then compound 4.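

In this assay the exchange of hydrogen for nitro again moves the number up, with a 140-fold higher number from compound 3 to compound 4 (2.13 log units; beyond the scatter) standing alongside the earlier 150-fold higher number from compound 1 to compound 2 (2.16 log units; beyond the scatter) as a second large rise. The rise is therefore no longer tied to one configuration at phosphorus or to a single place on the ring: it also holds for 2-nitrobenzyl, with the nitro group on an aromatic carbon ortho to a large group, although these two pairs are the only support for that pattern and neither goes against it. Nothing available gives a measured reason why the nitro group has this effect at this place.

Compound 2 and compound 4 differ in two places, at phosphorus and in where the nitro group sits on the ring, so the compounds shown cannot separate the contribution of either one to the size of the rise. Nitro is also the only group shown on the ring, which leaves open how an amine, a methoxy group or a carboxylic acid at the same place would behave in this assay on this core.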